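Turning the double bond of compound 2 from E to Z

The compounds below may be only part of what the source reports. "The series", "measured", "known", "first", "only" and "open" are said of these compounds alone.

In a functional assay on SK-MEL-28 cells (Homo sapiens) for inhibition (a lower number here means a stronger inhibitor, a higher number a weaker inhibitor), compound 1 (`COCCOc1cc(/C=C\c2ccc3ccccc3c2)ccc1OC`) gives 2990 nM as a measured number. Compound 2 (`COc1ccc(/C=C/c2ccc3ccccc3c2)cc1N`) gives > 5000 nM and this is a limit of the assay, not a number. The next compound is compound 3 (`COc1ccc(/C=C\c2ccc3ccccc3c2)cc1N`), and it differs from compound 2 as follows: the two compounds have the same atoms and bonds and differ only in configuration as drawn: 1 of 1 stereo elements differ; a double bond is drawn E in compound 2 and Z in compound 3. Nothing leaves and nothing enters, since a double bond drawn E in compound 2 is drawn Z in compound 3. For the measured compounds named here, no measured pair shows what this change does in this assay, so any size given is a judgement. A clear move towards stronger inhibition is expected. That expectation rests on compound 3 sharing the Z double bond with compound 1, which gives 2990 nM in this assay as a number. The expected change is an at least 8.3-fold lower number from compound 2 to compound 3 (0.92 log units; beyond the scatter) in size. Compound 3 is estimated at 600 nM, within an expected range of 60 nM to 5000 nM.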

Compound 3, half-maximal inhibitory concentration: > 20000 nM
Compound 3 ended at the assay's limit; the forecaster's own chance of this, stated with the estimate: 15%; middle value at least 33-fold (1.52 log units) from the limit.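

Exchanging 2-methoxyethoxy for amino on an aromatic carbon, with the Z double bond kept, gives an at least 6.6-fold higher number from compound 1 to compound 3 (0.82 log units; beyond the scatter). The Z double bond alone therefore does not give a measured number in this assay, and the group on that aromatic carbon matters as well. Compound 2 and compound 3 both stand at limits of the assay, not at numbers, and the step between them cannot be read.

The compounds shown leave open what the change from E to Z does when the 2-methoxyethoxy group is present, as only the Z form carries it here. They also leave open whether a hydroxyl group or a longer ether chain on that aromatic carbon would give a lower number than compound 1 in this assay.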